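The source may hold more compounds than are shown below. What is called first, only, known or untested is meant among the compounds shown, and "the series" means these compounds.

Compound 1 `CC(=O)N1CCC(c2ccc(-c3cc(C(=O)O)cc4cc(-c5ccc(C(F)(F)F)cc5)ccc34)cc2)CC1` and compound 2 `C#CCCCCN1CCC(c2ccc(-c3cc(C(=O)O)cc4cc(-c5ccc(C(F)(F)F)cc5)ccc34)cc2)CC1` share one core and differ only at an amine nitrogen in a ring. In a functional assay on the whole organism (strain ICR) for inhibition, with Mus musculus as the target, with stated times of 7 days and 2 h, at a dose of 10 umol/kg by the intraperitoneal route (a higher number here means more inhibition at the dose given (going by the name of the read-out), a lower number less inhibition), compound 1 gives 100%, while compound 2 gives 42.7%, the lower of the two numbers measured; the change was a number 57.3 percentage points lower from compound 1 to compound 2 (beyond the scatter). Compound 3 `CCC(=O)N1CCC(c2ccc(-c3cc(C(=O)O)cc4cc(-c5ccc(C(F)(F)F)cc5)ccc34)cc2)CC1` is compound 2 with propanoyl in place of hex-5-yn-1-yl on an amine nitrogen in a ring. Propanoyl, like acetyl, carries a carbonyl, and the single measured step points the opposite way with a large size. A large upward step is therefore expected: a number 52.3 percentage points higher from compound 2 to compound 3 (beyond the scatter). Compound 3 is estimated at 95%, within 70% to 100%.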

Compound 3, a percentage reported as inhibition, in the whole organism at one dose (the size of the read-out at that dose, not a potency): 71.6%
Beside the measured number, compound 3's estimate is 23.4 percentage points above it; the measured number falls inside the stated range.
By their numbers in this assay, from the lowest: compound 2; then compound 3; then compound 1.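

The new compound shows that a carbonyl-bearing group on this amine nitrogen does not by itself match acetyl: propanoyl in place of hex-5-yn-1-yl recovers only part of the loss (a number 28.9 percentage points higher from compound 2 to compound 3 (beyond the scatter)). Even a small change within the acyl group counts, as methyl in place of hydrogen on the chain carbon bound to the carbonyl carbon gives a clear drop (a number 28.4 percentage points lower from compound 1 to compound 3 (beyond the scatter)). Nothing available explains either step.

From the compounds shown here alone, whether a longer acyl chain such as butanoyl would lower the inhibition further remains open. So does the outcome with a plain hydrogen or a sulfonyl group on this nitrogen.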